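The source may hold more compounds than are shown below. What is called first, only, known or untested is meant among the compounds shown, and "the series" means these compounds.

In an ADME assay on microsomes from liver (Rattus norvegicus) for metabolic stability, with a stated time of 10 min, tested at 0.5 uM (a higher number here means that more of the compound is left, a lower number that less of the compound is left), compound 1 (`Cn1cc(-c2ccc(C(F)(F)F)cc2)c2cc(F)c(C(=O)NS(=O)(=O)C3CC3)cc21`) gives 100% and compound 2 (`Cn1cc(-c2ccc(C(F)(F)F)cc2)c2ccc(C(=O)NS(=O)(=O)C3CC3)cc21`) gives 92%, so the two lie within the scatter of each other. Compound 3 (`Cn1cc(-c2ccc(C(F)(F)F)cc2)c2cc(F)c(C(=O)NS(C)(=O)=O)cc21`) differs from compound 1 by methyl in place of cyclopropyl on a sulfonyl sulfur, with methyl in place of cyclopropyl on a sulfonyl sulfur. Among the compounds with values here, the only measured step, a number 8 percentage points lower from compound 1 to compound 2 (within the scatter), is hydrogen in place of fluoro on an aromatic carbon. Within the data shown here, it bears only indirectly, as no measured step changes the group on the sulfonyl sulfur. With no evidence for a larger shift, a change within the scatter is expected, an estimated a number 6 percentage points lower from compound 1 to compound 3 (within the scatter). For compound 3 the expected value is 94%, with an estimated range of 80% to 100%.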

Compound 3, percent of the compound remaining: 99%
The estimate for compound 3 lay 5 percentage points below the measured number; the range from low to high includes it.
By their numbers in this assay, from the lowest: compounds 2, 3 and 1 (each within the scatter of the next).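

In this assay, the group on the sulfonyl sulfur now has a measured step of its own: a number 1 percentage points lower from compound 1 to compound 3 (within the scatter) with methyl in place of cyclopropyl. At this position, the cyclopropyl ring is therefore not required for the read-out to stay within the scatter of compound 1. Nothing available explains this result.

Open, as far as these compounds go, is whether a longer chain, a phenyl ring or an amine on the sulfonyl sulfur would also stay within the scatter. Also open, from the compounds shown here alone, is how methyl there behaves with hydrogen in place of fluoro on the aromatic carbon.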